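This account rests on a few compounds, and the source may have more. Where it says the series, first, only, none or still open, it means among the compounds named here.

Measured so far in a functional assay on isolated protein for inhibition of Glucose-dependent insulinotropic receptor (Homo sapiens), read by HTRF and cAMP accumulation; on this read-out higher numbers stand for an effect only at larger amounts of compound and lower numbers for an effect already at smaller amounts:
compound 1 `Cc1nc(S(C)(=O)=O)ccc1Oc1ncnc(OC2CCN(C(=O)O[C@H](C)CF)CC2)c1F` gives 196 nM
compound 2 `Cc1nc(S(C)(=O)=O)ccc1Oc1ncnc(OC2CCN(C(=O)OC3(C(F)(F)F)COC3)CC2)c1F` gives 29.3 nM
compound 3 `Cc1nc(S(C)(=O)=O)ccc1Oc1ncnc(OC2CCN(C(=O)C3CCCC3)CC2)c1F` gives 72.8 nM

Compound 3 stands second highest of the three numbers in this assay; the nearest is compound 2, reached by a 2.5-fold higher number from compound 2 to compound 3 (0.40 log units; beyond the scatter), the furthest is compound 1, separated by a 2.7-fold lower number from compound 1 to compound 3 (0.43 log units; beyond the scatter). All three compounds share the same core and differ only in the group on the carbonyl carbon whose other neighbour is the amide-type nitrogen in a ring.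

Compound 4 `Cc1nc(S(C)(=O)=O)ccc1Oc1ncnc(OC2CCN(C(=O)c3noc(C(C)(C)F)n3)CC2)c1F` continues this variation: a group of 9 heavy atoms (5 carbon, 2 nitrogen, 1 oxygen, 1 fluorine; one five-membered aromatic ring with 3 hetero atoms) in place of a group of 5 heavy atoms (5 carbon; one five-membered non-aromatic ring of carbon only), on a carbonyl carbon. The change is a replacement of the cyclopentyl by a group with no common name, one five-membered aromatic ring with 3 hetero atoms, carrying three hydrogen-bond acceptors where the cyclopentyl has none.

Among the measured compounds shown here, the steps that bear on this position are those from compound 1 to compound 3 and from compound 2 to compound 3. Both are modest; both show that the group on this carbonyl carbon moves the number within a narrow band, and that a carbamate-type oxygen-linked group in compound 2 sits at the low end of the three. For the measured compounds named here, no measured step introduces an aromatic ring here, so the direction for compound 4 is not fixed by the data; a step of modest size in this assay, in either direction, is the expectation, with a slight lean toward a lower number.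

The estimate for compound 4 is 45 nM, expected within 12 nM to 160 nM, which corresponds to an expected step of a 1.6-fold lower number from compound 3 to compound 4 (0.21 log units; within the scatter).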

Compound 4, half-maximal effective concentration: 14 nM
Compound 4: middle estimate off by 3.2-fold (0.51 log units), on the high side, within the range that was stated.
By their numbers in this assay, from the lowest: compound 4; then compound 2; then compound 3; then compound 1.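

In this assay, the group with one five-membered aromatic ring with 3 hetero atoms gives a 5.2-fold lower number from compound 3 to compound 4 (0.72 log units; beyond the scatter) on the carbonyl carbon, so this position allows a wider spread than the first three compounds showed. The aromatic group also gives a 2.1-fold lower number from compound 2 to compound 4 (0.32 log units; beyond the scatter), which places it ahead of 3-(trifluoromethyl)oxetan-3-yl, the group with the same heavy-atom count that had stood lowest, and shows that the lowest number here does not need an oxygen link to the carbonyl carbon. Against the smaller 1-(fluoromethyl)ethyl group on oxygen, the change gives a 14-fold lower number from compound 1 to compound 4 (1.15 log units; beyond the scatter), the only step in the series printed as large.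

No measurement on hand gives a reason for these steps. The compounds shown cannot separate the contributions of the aromatic ring, its hetero atoms and its fluorine-bearing substituent, and a phenyl ring on the carbonyl carbon, or the same five-membered aromatic ring carrying a methyl group instead, would bear directly on that question.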